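Swapping the furan for a fluorophenyl on the ketone

This account rests on a few compounds, and the source may have more. Where it says the series, first, only, none or still open, it means among the compounds named here.

Measured so far:
compound 1 `O=C(/C=C/c1ccc2c(c1)B(O)OC2)c1ccco1` gives 59000 nM
compound 2 `CCc1ccc(C(=O)/C=C/c2ccc3c(c2)B(O)OC3)cc1` gives 20600 nM

Both numbers come from a toxicity assay on WI-38 cells (Homo sapiens) for cytotoxicity, read by MTT assay, with a stated time of 48 h; on this read-out lower numbers stand for stronger inhibition and higher numbers for weaker inhibition. Compound 1 stands at the highest of the two numbers, and the gap down to compound 2 lies beyond the usual scatter. Compound 3 `O=C(/C=C/c1ccc2c(c1)B(O)OC2)c1cccc(F)c1` has not yet been measured; it differs from compound 1 by 3-fluorophenyl in place of furan-2-yl on a carbonyl carbon. Within the data shown here, no measured step of this kind is at hand, so the expectation rests on compound 2 with 20600 nM: a modest move toward a lower number is expected, the estimated step being a 1.7-fold lower number from compound 1 to compound 3 (0.23 log units; within the scatter). Compound 3 is therefore estimated at 35000 nM, within 15000 nM to 80000 nM.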

Compound 3, half-maximal inhibitory concentration: 26700 nM
The estimate for compound 3 lay 1.3-fold (0.12 log units) above the measured number; measured number inside the range.
By their numbers in this assay, from the lowest: compounds 2 and 3 (each within the scatter of the next); then compound 1.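

In this assay, 3-fluorophenyl in place of furan-2-yl on a carbonyl carbon gives a 2.2-fold lower number from compound 1 to compound 3 (0.34 log units; beyond the scatter) and is the first single-place step shown at this position. It shows that, with the shared core held constant, exchanging one aromatic ring for another moves the number modestly but beyond the scatter. Nothing given here accounts for this step. Still open, from the compounds shown here alone, is whether the fluorine or the six-membered ring carries the change, which a plain phenyl group would separate. Also open, going by these compounds, is how a ring bearing an amine or a carboxylic acid would read.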